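Adding a second methyl to a phenol oxygen

The source may hold more compounds than are shown below. What is called first, only, known or untested is meant among the compounds shown, and "the series" means these compounds.

Compound 1 `COc1cc(/C=C/C=C/C(=O)O)ccc1O`: 42500 nM
Compound 2 `O=C(O)/C=C/C=C/c1ccc(O)c(O)c1`: 18200 nM

Within the data shown here, in a physicochemical assay, read by spectrophotometry, with a stated time of 45 min (a lower number here means a stronger inhibitor, a higher number a weaker inhibitor), compound 1 stands with the highest of the two numbers; the one measured step, a 2.3-fold lower number from compound 1 to compound 2 (0.37 log units; beyond the scatter), comes from hydrogen in place of methyl on an oxygen on an aromatic ring. Compound 3 `COc1ccc(/C=C/C=C/C(=O)O)cc1OC` differs from compound 1 by methyl in place of hydrogen on an oxygen on an aromatic ring, the same kind of change run the other way. That step is the only one bearing on it, so a modest rise in number, beyond the scatter, is expected in this assay. Compound 3 is therefore estimated at 90000 nM, between 40000 nM and 200000 nM, which means an expected step of a 2.1-fold higher number from compound 1 to compound 3 (0.33 log units; beyond the scatter).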

Compound 3, half-maximal inhibitory concentration: > 75000 nM
Compound 3 was reported as a limit (the forecaster's own chance of this, stated with the estimate: 15%); the middle value does not contradict the limit.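

With methyl in place of hydrogen on this oxygen, no hydroxy remains on the aromatic ring, and this assay records an at least 1.7-fold higher number from compound 1 to compound 3 (0.24 log units; that floor lies within the scatter). The value of compound 3 is a limit, not a number: the limit of > 75000 nM in this assay, at which 1 of the 3 values shown sits. The hydroxy to methoxy change at this position therefore has only a floor, and its true size cannot be read.

The compounds shown leave open how a longer chain such as ethyl on this oxygen would compare. They also leave open what an amine in place of the hydroxy would do.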